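Ethyl on the oxygen of compound 2

This account rests on a few compounds, and the source may have more. Where it says the series, first, only, none or still open, it means among the compounds named here.

Compound 1 `CC(=O)Oc1cc(C)c(Cl)c2c1C(=O)C=CC2=O` gives 25500 nM
Compound 2 `Cc1cc(O)c2c(c1Cl)C(=O)C=CC2=O` gives 29500 nM

In a functional assay on DU-145 cells (Homo sapiens) for cytotoxicity, read by XTT assay, with a stated time of 24 h (on this read-out lower numbers stand for stronger inhibition and higher numbers for weaker inhibition), compound 2 cannot be told apart from compound 1 on these two numbers. Compound 3 `CCOc1cc(C)c(Cl)c2c1C(=O)C=CC2=O` has ethyl in place of hydrogen on an oxygen on an aromatic ring of compound 2 (ethyl in place of hydrogen on an oxygen on an aromatic ring). Going by the values given here, the one measured step at this oxygen is a 1.2-fold higher number from compound 1 to compound 2 (0.06 log units; within the scatter) and it exchanges acetyl for hydrogen. Among the compounds with values here, no compound with ethyl there has been measured, so this evidence is thin. In this assay no change beyond the scatter is expected in either direction, and the expected step is a 1.2-fold lower number from compound 2 to compound 3 (0.09 log units; within the scatter) as a small one. Compound 3 is estimated at 24000 nM with an expected range of 11000 nM to 50000 nM around that figure.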

Compound 3, half-maximal inhibitory concentration: 25400 nM
For compound 3 the middle estimate is 1.1-fold (0.02 log units) below the measured one; low and high end bracket the measured number.
By their numbers in this assay, from the lowest: compounds 3, 1 and 2 (each within the scatter of the next).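

In this assay, the ethyl ether sits level with both earlier compounds: a 1.2-fold lower number from compound 2 to compound 3 (0.06 log units; within the scatter), and a 1.0-fold lower number from compound 1 to compound 3 (0.00 log units; within the scatter). Hydroxy to ethoxy thus joins the acetyl exchange in making no difference that can be told apart here, so three different groups on this oxygen now give indistinguishable numbers. No measurement shown offers a reason for this.

As far as these compounds go, whether a longer chain or a group carrying an amine or a carboxylic acid on this oxygen would also stay level remains open. So does whether changes elsewhere on the shared core would matter more.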